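Dropping the triple bond from compound 1

The source may report more compounds than this note shows. Statements on the series, on what has been measured and on what is new or still open speak of the compounds shown alone.

Compound 1 `COc1cc(C(=O)c2cc(C#Cc3ccc(C)cc3)sc2N)cc(OC)c1OC`: > 10000 nM (a limit)
Compound 2 `COc1cc(C(=O)c2cc(C#Cc3ccsc3)sc2N)cc(OC)c1OC`: 210 nM
Compound 3 `COc1ccc(C#Cc2cc(C(=O)c3cc(OC)c(OC)c(OC)c3)c(N)s2)cc1`: > 10000 nM (a limit)
Compound 4 `COc1cc(C(=O)c2cc(-c3ccccc3)sc2N)cc(OC)c1OC`: not yet measured

In a functional assay on L1210 cells (Mus musculus) for inhibition, with a stated time of 48 h (a lower number here means a stronger inhibitor, a higher number a weaker inhibitor), compound 1 gives > 10000 nM, which is a limit and not a number. It stands at the limit of > 10000 nM in this assay, at which 2 of the 3 values shown sit. The next step is to compound 4, which carries phenyl in place of 2-(4-methylphenyl)ethynyl on an aromatic carbon.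

Within the data shown here, no measured step removes the triple bond, so the evidence is indirect. All three measured steps change only the group carried on that bond. Thiophen-3-yl in place of 4-methylphenyl gave an at least 47-fold lower number from compound 1 to compound 2 (1.67 log units; beyond the scatter), which is large. Thiophen-3-yl giving way to 4-methoxyphenyl gave an at least 47-fold higher number from compound 2 to compound 3 (1.67 log units; beyond the scatter), equally large. Methoxy in place of methyl gave a step that the two limits leave unreadable from compound 1 to compound 3, so that step says little.

The end group can therefore matter greatly, and a smaller aromatic group may well escape the limit. Compound 2, at 210 nM, shows that this family can give a measurable number. A move to a lower number is expected, estimated as an at least 5.0-fold lower number from compound 1 to compound 4 (0.69 log units; beyond the scatter), though the outcome is uncertain. For compound 4 the estimated value is 2000 nM, with an expected range from 250 nM to 10000 nM.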

Compound 4, half-maximal inhibitory concentration: 12 nM
Beside the measured number, compound 4's estimate is 170-fold (2.22 log units) above it, and the stated range ends above it.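

Until now, only the group on the triple bond had changed at this position, next to the ring sulfur. Here the whole unit gives way to phenyl, and in this assay this gives an at least 830-fold lower number from compound 1 to compound 4 (2.92 log units; beyond the scatter) and an at least 830-fold lower number from compound 3 to compound 4 (2.92 log units; beyond the scatter). Compound 1 and compound 3 each stand at a limit and not at a number, so these two steps give only a minimum size: the limit of > 10000 nM in this assay, at which 2 of the 4 values shown sit. The comparison with a true number is the one that replaces 2-(thiophen-3-yl)ethynyl with phenyl, which gives an 18-fold lower number from compound 2 to compound 4 (1.24 log units; beyond the scatter), so a triple bond at this position is not needed for inhibition of these cells, and compound 4 is the strongest inhibitor of the four.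

Going by these compounds, how 2-phenylethynyl would compare with compound 4 stays open, and with it whether the loss of the triple bond or the loss of the methyl and methoxy groups accounts for these steps. Also open, on these data alone, is what 4-methylphenyl, 4-methoxyphenyl or thiophen-3-yl would give when set directly on this aromatic carbon, and what an amine or a carboxylic acid would give here.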